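The compounds below may be only part of what the source reports. "The series", "measured", "known", "first", "only" and "open" are said of these compounds alone.

Three compounds share one core and differ only in the aromatic group attached to it. Compound 3 `Clc1ccc(-c2cn3ccnc3c(-c3ccc4ncn(C5CCCCC5)c4c3)n2)cc1` gives 16.4% in a functional assay on HT-29 cells (Homo sapiens) for inhibition, read by sulforhodamine B assay, with a stated time of 48 h, tested at 10 uM (a higher number here means more inhibition at the concentration tested (going by the name of the read-out), a lower number less inhibition), and stands second highest of the three numbers, with compound 1 `O=Cc1ccc(-c2cn3ccnc3c(-c3ccc4ncn(C5CCCCC5)c4c3)n2)cc1` close by at 17.5% and compound 2 `c1ccc2c(-c3cn4ccnc4c(-c4ccc5ncn(C6CCCCC6)c5c4)n3)cccc2c1` further off at 4.11%. Compound 4 `Fc1ccccc1-c1cn2ccnc2c(-c2ccc3ncn(C4CCCCC4)c3c2)n1` has not been measured yet. The change from compound 3 to compound 4 is 2-fluorophenyl in place of 4-chlorophenyl on an aromatic carbon. Among the measured compounds shown here, two measured steps bear on it: a number 1.1 percentage points lower from compound 1 to compound 3 (within the scatter), where swapping one small group on the ring barely moved the number, and a number 12.3 percentage points higher from compound 2 to compound 3 (beyond the scatter), where exchanging the whole ring system did. Compound 4 keeps one six-membered aromatic ring of carbon only. The step expected is therefore small, a number 4.4 percentage points lower from compound 3 to compound 4 (within the scatter). Compound 4 is estimated at 12%, ranging from 2% to 24%.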

Compound 4, a percentage reported as inhibition, at one concentration (the size of the read-out at that concentration, not a potency): 7.26%
Beside the measured number, compound 4's estimate is 4.7 percentage points above it; the range from low to high includes it.
By their numbers in this assay, from the lowest: compounds 2, 4, 3 and 1 (each within the scatter of the next, the first and the last beyond it).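

At this position, keeping one six-membered aromatic ring of carbon only does not settle the number in this assay. With 2-fluorophenyl the result is a number 10.2 percentage points lower from compound 1 to compound 4 (beyond the scatter), yet also a number 9.1 percentage points lower from compound 3 to compound 4 (within the scatter) and a number 3.2 percentage points higher from compound 2 to compound 4 (within the scatter), so compound 4 bridges the gap that separated 4-chlorophenyl from naphthalen-1-yl. Nothing available gives a reason for these steps.

From the compounds shown here alone, compound 4 changes both the halogen and its place on the ring, so the effect of each alone stays open. How an amine or a carboxylic acid on this ring would read is also unknown.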